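A few compounds are considered here, and "the series" means these few. Any claim that something is new, unique, unknown or untested is made for them only; others in the source may bear on it.

Compound 1, `CC(=O)c1ccc(OCc2ccccc2Cl)cc1`, gives 311 nM in an assay on isolated protein for inhibition of Amine oxidase [flavin-containing] B (Homo sapiens), read by Amplex Red, with a stated time of 15 min; on this read-out higher numbers stand for weaker inhibition and lower numbers for stronger inhibition. Compound 2, `CC(=O)c1cccc(OCc2ccc(F)cc2)c1`, gives 86.4 nM in this assay. Compound 3, `CC(=O)c1cccc(OCc2cccc(Cl)c2)c1`, gives 34.2 nM in this assay.

Among these three, compound 3 has the lowest number. The nearest to it, compound 2, lies beyond the scatter above it, and compound 1 lies further above still, also beyond the scatter. Compound 4, `CC(=O)c1cccc(OCc2cccc(C)c2)c1`, differs from compound 3 by methyl in place of chloro on an aromatic carbon, meta to a large group. Among the compounds with values here, no pair among the measured compounds differs in one place only, so no single-change step is at hand to set the size of such an exchange. With only the change itself to go on, the expected move in this assay is small, upward if anything, and it may well stay within the scatter. Compound 4 is therefore estimated at 60 nM, with a range from 20 nM to 200 nM. That estimate means an expected step of a 1.8-fold higher number from compound 3 to compound 4 (0.24 log units; within the scatter), not an observed one.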

Compound 4, half-maximal inhibitory concentration: 893 nM
Beside the measured number, compound 4's estimate is 15-fold (1.17 log units) below it; measured number outside the range, above it.
By their numbers in this assay, from the lowest: compound 3; then compound 2; then compound 1; then compound 4.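

In this assay, the exchange of chloro for methyl on this aromatic carbon, meta to a large group, gives the first single-place comparison among these compounds: a 26-fold higher number from compound 3 to compound 4 (1.42 log units; beyond the scatter). The position therefore separates the two groups sharply, although each is a single heavy atom with no hydrogen-bond donors, no hydrogen-bond acceptors and no net charge. Nothing available here bears on what lies behind this step.

As far as these compounds go, whether other groups at this place, such as methoxy, an amine or a carboxylic acid, would fall nearer to compound 3 or to compound 4 remains open. Compound 1 and compound 2 each differ from compound 3 in more than one place, so they leave open whether the exchange would have the same size elsewhere on the shared core.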